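A single fluorine added to a chalcone-triazole series

This account rests on a few compounds, and the source may have more. Where it says the series, first, only, none or still open, it means among the compounds named here.

Measured compounds:
compound 1, `COc1cc(/C=C/C(=O)c2cccc(-n3cc(-c4ccc(F)cc4)nn3)c2)ccc1O`, 6450 nM
compound 2, `COc1ccc(/C=C/C(=O)c2cccc(-n3cc(-c4ccccc4)nn3)c2)cc1O`, 1510 nM

Of the compounds shown here, two of a shared core have been measured in a functional assay on RAW264.7 cells (Mus musculus) for inhibition, with a stated time of 4 days; a higher number here means a weaker inhibitor, a lower number a stronger inhibitor. Compound 2 stands at the lower of the two numbers; the only other one, compound 1, gives a higher number, and that gap lies beyond the usual scatter. Compound 1 and compound 2 differ in more than one place, so their gap cannot be tied to a single change.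

Compound 3, `COc1ccc(/C=C/C(=O)c2cccc(-n3cc(-c4ccc(F)cc4)nn3)c2)cc1O`, has not yet been measured. It differs from compound 2 in one place: fluoro in place of hydrogen on an aromatic carbon. Going by the values given here, no measured pair shows this change alone. The expected step of a 1.7-fold higher number from compound 2 to compound 3 (0.22 log units; within the scatter) is modest, toward a somewhat higher number, and could well fall within the scatter. Compound 3 is therefore expected to give about 2500 nM, within a range from 900 nM to 7000 nM.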

Compound 3, half-maximal inhibitory concentration: 2500 nM
Compound 3: the middle estimate sits on the measured number at the digits printed, within the range that was stated.
By their numbers in this assay, from the lowest: compounds 2 and 3 (each within the scatter of the next); then compound 1.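

In this assay the change from phenyl to 4-fluorophenyl gives a 1.7-fold higher number from compound 2 to compound 3 (0.22 log units; within the scatter) and so stays within the scatter: at this place, para to a large group, fluoro and hydrogen cannot be told apart. Going by these compounds alone, by contrast, 3-hydroxy-4-methoxyphenyl in place of 4-hydroxy-3-methoxyphenyl gives a 2.6-fold lower number from compound 1 to compound 3 (0.41 log units; beyond the scatter) and lies beyond the scatter, so this single change, seen alone for the first time, shifts the number more clearly than the fluoro does. Nothing available here bears on why either step arises.

As far as these compounds go, whether a chloro group, a methoxy group or an amine at the same place would shift the number remains open. Also open, from the compounds shown here alone, is whether hydrogen and fluoro would still match alongside the 4-hydroxy-3-methoxyphenyl group.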